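The source may hold more compounds than are shown below. What is called first, only, known or untested is meant among the compounds shown, and "the series" means these compounds.

Compound 1 `CCNC(=O)Nc1nc2cc(-c3cnc(N4CCC(C(=O)O)CC4)nc3)cc(-c3ccccn3)c2s1` is known in a physicochemical assay for solubility, read by turbidimetry, in phosphate buffer, with a stated time of 24 h, at pH 7.4 (a higher number here means a more soluble compound, a lower number a less soluble compound), only by a limit: compound 1 gives > 800 ug/mL, which is a limit of the assay. Compound 2 `CCNC(=O)Nc1nc2cc(-c3cncc(N4CCC(C)(C(=O)O)CC4)c3)cc(-c3ccccn3)c2s1` likewise reaches a limit in this assay, giving > 800 ug/mL. Both values thus sit at the limit of > 800 ug/mL in this assay, at which 2 of the 2 values shown sit. Compound 3 `CCNC(=O)Nc1nc2cc(-c3cnc(N4CCC(C)(C(=O)O)C4)nc3)cc(-c3ccccn3)c2s1` has not been measured; it differs from compound 1 by 3-carboxy-3-methylpyrrolidin-1-yl in place of 4-carboxypiperidin-1-yl on an aromatic carbon. Among the measured compounds shown here, no step between measured compounds is available, so the step expected here, a number no higher from compound 1 to compound 3 (the limit leaves the size open), is none beyond the scatter. Compound 3 is estimated at 800 ug/mL, between 400 ug/mL and 1600 ug/mL.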

Compound 3, solubility: > 800 ug/mL
Compound 3: a limit, no number; the forecaster's own chance of this, stated with the estimate: 75%; the middle value sits exactly at the limit.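

In this assay compound 3 gives > 800 ug/mL, which is a limit of the assay. Among the compounds shown here, compound 1 is also known only by a limit, so no step between compound 1 and compound 3 can be read. The compounds shown leave open whether 3-carboxy-3-methylpyrrolidin-1-yl in place of 4-carboxypiperidin-1-yl changes the read-out at all.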